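The source may report more compounds than this note shows. Statements on the series, on what has been measured and on what is new or still open speak of the compounds shown alone.

Measured in a functional assay on SGC-7901 cells (Homo sapiens) for antiproliferative activity, read by MTT assay, with a stated time of 24 h; on this read-out higher numbers stand for weaker inhibition and lower numbers for stronger inhibition:
Compound 1 `O=C(NNc1cccc(Cl)c1)c1cccc(NS(=O)(=O)c2cnc(O)nc2O)c1`: 11800 nM
Compound 2 `Cc1ccccc1NNC(=O)c1ccccc1NS(=O)(=O)c1cnc(O)nc1O`: > 20000 nM, a limit of the assay
Compound 3 `O=C(NNc1ccccc1F)c1ccccc1NS(=O)(=O)c1cnc(O)nc1O`: > 20000 nM, a limit of the assay

Compound 1 is the only one of the three with an actual number. The other two results are not numbers: the limit of > 20000 nM in this assay, at which 2 of the 3 values shown sit.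

Compound 4 `O=C(NNC(=O)c1ccccc1F)c1cccc(NS(=O)(=O)c2cnc(O)nc2O)c1` keeps the core of compound 1 and differs in one place, with (2-fluorophenyl)carbonyl in place of 3-chlorophenyl on an amine nitrogen.

Among the compounds with values here, the only step between measured compounds is a step that the two limits leave unreadable from compound 2 to compound 3. It is a different change, fluoro in place of methyl on an aromatic carbon, and offers no size to carry over. Within the data shown here, with no measured step to guide it, the expectation rests on compound 1 with its 11800 nM, and no shift beyond the scatter is expected in this assay. The expected change is a 1.0-fold higher number from compound 1 to compound 4 (0.01 log units; within the scatter). For compound 4 the estimated value is 12000 nM, with an expected range of 5000 nM to 28000 nM.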

Compound 4, half-maximal inhibitory concentration: > 20000 nM
Compound 4 ended at the assay's limit (the forecaster's own chance of this, stated with the estimate: 35%); at least 1.6-fold (0.22 log units) between middle value and limit.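

On an amine nitrogen whose other neighbour is an amide-type nitrogen, (2-fluorophenyl)carbonyl in place of 3-chlorophenyl gives, in this assay, an at least 1.6-fold higher number from compound 1 to compound 4 (0.22 log units; that floor lies within the scatter). This is the only change shown at this place on the core of compound 1, and compound 4 carries a limit rather than a number, so only the floor of the step can be read, and that floor does not separate compound 4 from compound 1 beyond the scatter. Compound 1 remains the only compound with an actual number, and the limit is now more widely shared: the limit of > 20000 nM in this assay, at which 3 of the 4 values shown sit.

As far as these compounds go, how far compound 4 lies past its limit stays open, and the step between the two limits of compounds 2 and 3 cannot be read. Also open, from the compounds shown here alone, is whether a benzyl group or an acetyl group on this nitrogen would give a number within the range of the assay.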